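Triazole-linked trimethoxyphenyl series: phenyl for methyl step

The source may hold more compounds than are shown below. What is called first, only, known or untested is meant among the compounds shown, and "the series" means these compounds.

Measured compounds in a functional assay on DU-145 cells (Homo sapiens) for cytotoxicity, read by MTT assay, with a stated time of 48 h; a higher number here means a weaker inhibitor, a lower number a stronger inhibitor:
- compound 1 `COc1cc(-c2cc(COCc3cn(Cc4cc(-c5ccccc5)cnc4Cl)nn3)on2)cc(OC)c1OC`, compound 1 gives 78500 nM
- compound 2 `COc1cc(-c2cc(COCc3cn(Cc4cc(C)cnc4Cl)nn3)on2)cc(OC)c1OC`, compound 2 gives 39800 nM
- compound 3 `COc1cc(C2=NOC(COCc3cn(Cc4cc(C)cnc4Cl)nn3)C2)cc(OC)c1OC`, compound 3 gives 58900 nM

Compound 4 `COc1cc(C2=NOC(COCc3cn(Cc4cc(-c5ccccc5)cnc4Cl)nn3)C2)cc(OC)c1OC` is not yet measured. Its core is that of compound 3; the difference between the core of compound 3 and the core of compound 2 is not broken down here. From compound 3 to compound 4 the change is phenyl in place of methyl on an aromatic carbon. The same kind of change, (phenyl in place of methyl on an aromatic carbon), is already measured within the other core, where it gave a 2.0-fold higher number from compound 2 to compound 1 (0.29 log units; within the scatter). The two place descriptions are the same word for word. Among the measured compounds shown here, for compound 3 to compound 4 the step is expected to be about the same size, namely a 1.9-fold higher number from compound 3 to compound 4 (0.27 log units; within the scatter), resting on the one measured pair alone. Compound 4 is therefore estimated at 110000 nM, within 50000 nM to 250000 nM.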

Compound 4, half-maximal inhibitory concentration: 11400 nM
The estimate for compound 4 lay 9.6-fold (0.98 log units) above the measured number; measured number below the stated range.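

In this assay, phenyl in place of methyl on an aromatic carbon gives a 5.2-fold lower number from compound 3 to compound 4 (0.71 log units; beyond the scatter). The direction and size of this step do not carry over between the two cores: the same change on two cores in this assay, a 2.0-fold higher number (0.29 log units; within the scatter) from compound 2 to compound 1 and a 5.2-fold lower number (0.71 log units; beyond the scatter) from compound 3 to compound 4, 10-fold (1.01 log units) apart, beyond the scatter of two such steps

With one pair on each core, the result shows a dependence on the core for these four compounds only; it gives no reason for that dependence and no forecast for a further core. Open, from the compounds shown here alone, is whether the drop in the number on the core of compound 3 is specific to phenyl or also appears with another group on the same aromatic carbon, such as ethyl, methoxy or an amine.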